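A few compounds are considered here, and "the series" means these few. Any claim that something is new, unique, unknown or untested is made for them only; others in the source may bear on it.

Of the compounds shown here, three have been measured in a functional assay on cells (Pituitary gland cell) for antagonist activity at Gonadotropin-releasing hormone receptor (Rattus norvegicus); a lower number here means a stronger inhibitor, a higher number a weaker inhibitor: compound 1 `O=C(Nc1cc2c(OCCC3CCCCN3)c(-c3ccc(Cl)c(Cl)c3)c(O)nc2cc1Cl)NC1CC1` gives 18 nM; compound 2 `O=C(Nc1cc2c(OCCC3CCCCN3)c(-c3ccc4ccccc4c3)c(O)nc2cc1Cl)NC1CC1` gives 68 nM; compound 3 `O=C(Nc1cc2c(OCCC3CCCCN3)c(-c3cccc(Br)c3)c(O)nc2cc1Cl)NC1CC1` gives 6 nM.

Compound 3 stands lowest of the three: the change from compound 1 to compound 3 gave a 3.0-fold lower number from compound 1 to compound 3 (0.48 log units; beyond the scatter), and that from compound 2 to compound 3 gave an 11-fold lower number from compound 2 to compound 3 (1.05 log units; beyond the scatter). Compound 4 `Cc1ccc(-c2c(O)nc3cc(Cl)c(NC(=O)NC4CC4)cc3c2OCCC2CCCCN2)cc1C` differs from compound 3 in one place: 3,4-dimethylphenyl in place of 3-bromophenyl on an aromatic carbon. Among the measured compounds shown here, the step that bears most on this is the one from compound 1 to compound 3, where a 3,4-disubstituted ring stood in place of the 3-bromophenyl, with a 3.0-fold lower number from compound 1 to compound 3 (0.48 log units; beyond the scatter). Returning to a 3,4-disubstituted ring is therefore expected to give a modest rise in this assay, estimated as a 3.3-fold higher number from compound 3 to compound 4 (0.52 log units; beyond the scatter). Compound 4 is expected to give about 20 nM, within 7 nM to 60 nM.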

Compound 4, half-maximal inhibitory concentration: 6 nM
Beside the measured number, compound 4's estimate is 3.3-fold (0.52 log units) above it; measured number below the stated range.
By their numbers in this assay, from the lowest: compounds 3 and 4 (each within the scatter of the next); then compound 1; then compound 2.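

In this assay, the step to 3,4-dimethylphenyl shows no change at the digits printed from compound 3 to compound 4 (within the scatter), so a 3,4-disubstituted ring at this position does not by itself bring a higher number. Within that same pattern, the two methyl groups give a 3.0-fold lower number from compound 1 to compound 4 (0.48 log units; beyond the scatter), so the identity of the substituents matters, while the step from the fused naphthalen-2-yl group is an 11-fold lower number from compound 2 to compound 4 (1.05 log units; beyond the scatter). Nothing shown here offers an explanation for these differences.

As far as these compounds go, it remains open where a methoxy group, an amine or a carboxylic acid in place of the methyl groups would fall in this assay.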